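Open-chain replacement on the E double bond

The source may hold more compounds than are shown below. What is called first, only, known or untested is meant among the compounds shown, and "the series" means these compounds.

Among the compounds with values here, in a functional assay on M21 cells (Homo sapiens) for inhibition, read by sulforhodamine B assay, with a stated time of 48 h (on this read-out lower numbers stand for stronger inhibition and higher numbers for weaker inhibition), compound 2 `Cc1cc(C)cc(/C=C/c2ccc(N3CCNC3=O)cc2)c1` gives 17000 nM, the highest of the three numbers so far. Compound 1 `CCNC(=O)Nc1ccc(/C=C\c2cc(C)cc(C)c2)cc1`, at 16000 nM, lies within the scatter of it, while compound 3 `Cc1cc(C)cc(/C=C\c2ccc(N3CCNC3=O)cc2)c1` stands far lower at 10 nM.

The next compound, compound 4 `CCNC(=O)Nc1ccc(/C=C/c2cc(C)cc(C)c2)cc1`, keeps the E double bond of compound 2 and differs from it by (ethylcarbamoyl)amino in place of 2-oxoimidazolidin-1-yl on an aromatic carbon. Within the data shown here, two measured steps bear on this change. The same exchange, run in reverse on the Z double bond, gave the large 1600-fold lower number from compound 1 to compound 3 (3.20 log units; beyond the scatter). The equally large a 1700-fold lower number from compound 2 to compound 3 (3.23 log units; beyond the scatter) goes with the fact that compounds 2 and 3 differ only in the configuration as drawn. Among the measured compounds shown here, the number for compound 2 therefore already lies as high as that for compound 1, the open-chain Z compound, and the large step in the reverse exchange has been seen only on the Z double bond. It is not expected to carry over to the E double bond. No change beyond the scatter is expected, and the estimated step is a 1.2-fold higher number from compound 2 to compound 4 (0.07 log units; within the scatter). Compound 4 is estimated at 20000 nM, with an expected range of 7000 nM to 60000 nM.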

Compound 4, half-maximal inhibitory concentration: > 20000 nM
Compound 4 was reported as a limit (the forecaster's own chance of this, stated with the estimate: 30%); the middle value sits exactly at the limit.
By their numbers in this assay, from the lowest: compound 3; then compounds 1 and 2 (each within the scatter of the next). At a limit, above all of these: compound 4.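

In this assay compound 4 gives > 20000 nM as a limit and not as a number. Read as floors, the exchange of 2-oxoimidazolidin-1-yl for (ethylcarbamoyl)amino on the E double bond gives an at least 1.1-fold higher number from compound 2 to compound 4 (0.07 log units; that floor lies within the scatter) and the change from Z to E with (ethylcarbamoyl)amino in place gives an at least 1.2-fold higher number from compound 1 to compound 4 (0.09 log units; that floor lies within the scatter) with both floors within the scatter. Of the four compounds only compound 3, which combines 2-oxoimidazolidin-1-yl with the Z double bond, gives a low number at 10 nM and the exchange cannot yet be compared between the two double bonds: the same change on two cores in this assay, a 1600-fold lower number (3.20 log units; beyond the scatter) from compound 1 to compound 3 and an at least 1.1-fold lower number (0.07 log units; that floor lies within the scatter) from compound 4 to compound 2; the limit leaves it open whether they differ.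

Open, from the compounds shown here alone, is whether a low number on the Z double bond also holds for another group at this place, such as an amine or a carboxylic acid. Also open, going by these compounds, is the true size of both steps to compound 4.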